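A few compounds are considered here, and "the series" means these few. Any claim that something is new, unique, unknown or untested is made for them only; others in the source may bear on it.

Among the measured compounds shown here, compound 2 `CS(=O)(=O)NCCCNC(=O)CN1CN(c2ccccc2)C2(CCN(C(=O)c3ccc(C4CCCCC4)cc3)CC2)C1=O` gives the lowest of the two numbers so far: in an assay on HEK293 cells for displacement of a labelled ligand from NPC1-like intracellular cholesterol transporter 1 (Homo sapiens) (a lower number here means a stronger inhibitor, a higher number a weaker inhibitor), compound 2 gives 3800 nM, while compound 1 `CS(=O)(=O)N1CCN(C(=O)CN2CN(c3ccccc3)C3(CCN(C(=O)c4ccc(C5CCCCC5)cc4)CC3)C2=O)CC1` gives 6300 nM, and the step of a 1.7-fold lower number from compound 1 to compound 2 (0.22 log units; within the scatter) stays within the scatter. Compound 3 `CCOC(=O)C1CCCN(C(=O)CN2CN(c3ccccc3)C3(CCN(C(=O)c4ccc(C5CCCCC5)cc4)CC3)C2=O)C1` carries 3-(ethoxycarbonyl)piperidin-1-yl in place of (3-(methanesulfonamido)propyl)amino on a carbonyl carbon. For the measured compounds named here, the single measured step bears on this change only loosely, since compound 1 also bore a six-membered ring on that carbonyl carbon and differed little from compound 2. Compound 3 is therefore expected to show no step beyond the scatter, about a 1.3-fold higher number from compound 2 to compound 3 (0.12 log units; within the scatter), giving an estimated 5000 nM with a range of 2000 nM to 15000 nM.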

Compound 3, half-maximal inhibitory concentration: 4200 nM
The estimate for compound 3 lay 1.2-fold (0.08 log units) above the measured number; measured number inside the range.
By their numbers in this assay, from the lowest: compounds 2, 3 and 1 (each within the scatter of the next).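

In this assay the open chain on this carbonyl carbon gives way to 3-(ethoxycarbonyl)piperidin-1-yl with a 1.1-fold higher number from compound 2 to compound 3 (0.04 log units; within the scatter) and the same group replaces 4-(methylsulfonyl)piperazin-1-yl with a 1.5-fold lower number from compound 1 to compound 3 (0.18 log units; within the scatter) in the other comparison. A group with no sulfur and 0 hydrogen-bond donors therefore stands within the scatter of both sulfonyl-bearing groups on this carbonyl carbon. Nothing at hand speaks to why these numbers lie so close. Still open, going by these compounds, is whether a carboxylic acid in place of the ethyl ester, or an amine on the piperidine ring, would move the number beyond the scatter.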